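This account rests on a few compounds, and the source may have more. Where it says the series, first, only, none or still open, it means among the compounds named here.

Measured so far in a functional assay on HSC-2 cells (Homo sapiens) for cytotoxicity, with a stated time of 24 h; a lower number here means that less compound is tolerated, a higher number that more compound is tolerated:
- Compound 1 `O=C1/C(=C/c2ccc(F)cc2)CCC/C1=C\c1ccc([N+](=O)[O-])cc1` gives 19000 nM
- Compound 2 `O=C1/C(=C/c2ccc(Cl)cc2)CCC/C1=C\c1ccc([N+](=O)[O-])cc1` gives 1500 nM
- Compound 3 `CN(C)c1ccc(/C=C2\CCC/C(=C\c3ccc([N+](=O)[O-])cc3)C2=O)cc1` gives 11000 nM

These three differ only in one group on one aromatic ring. Compound 3 at 11000 nM cannot be told apart from the fluoro compound (a 1.7-fold lower number from compound 1 to compound 3 (0.24 log units; within the scatter)) but stands clearly apart from the chloro compound (a 7.3-fold higher number from compound 2 to compound 3 (0.87 log units; beyond the scatter)). The swap between fluoro and chloro gave the largest step (a 13-fold lower number from compound 1 to compound 2 (1.10 log units; beyond the scatter)).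

Compound 4 `Cc1ccc(/C=C2\CCC/C(=C\c3ccc([N+](=O)[O-])cc3)C2=O)cc1` carries methyl in place of dimethylamino on an aromatic carbon and is otherwise unchanged. For the measured compounds named here, no methyl compound has been measured, so these three steps are the only guide. They show that swaps at this spot can do almost nothing or a great deal. Neither measured replacement of dimethylamino gave a higher number, so a modest move to a lower number is expected in this assay, though no real change remains possible. The expected step is a 2.2-fold lower number from compound 3 to compound 4 (0.34 log units; beyond the scatter) in this estimate. The estimate for compound 4 is 5000 nM with an expected range from 1500 nM to 16000 nM.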

Compound 4, half-maximal cytotoxic concentration: 6600 nM
Estimate against measurement, compound 4: 1.3-fold (0.12 log units) below; the measured number falls inside the stated range.
By their numbers in this assay, from the lowest: compound 2; then compounds 4, 3 and 1 (each within the scatter of the next, the first and the last beyond it).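

In this assay, methyl and dimethylamino cannot be told apart (a 1.7-fold lower number from compound 3 to compound 4 (0.22 log units; within the scatter)), so the smaller group, without a hydrogen-bond acceptor, gives a number that the usual scatter cannot separate from that of compound 3. Methyl still stands clear of chloro (a 4.4-fold higher number from compound 2 to compound 4 (0.64 log units; beyond the scatter)), which leaves compound 2 as the only one of the four set apart from all the others. Methyl also stands clear of fluoro (a 2.9-fold lower number from compound 1 to compound 4 (0.46 log units; beyond the scatter)), although dimethylamino does not, so these groups form no neat sets: compound 3 lies within the scatter of both compound 1 and compound 4.

From the compounds shown here alone, whether bromo, methoxy or a carboxylic acid at this spot would sit with chloro or with the other groups stays open. Nothing measured here bears on why chloro stands apart.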